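The source may report more compounds than this note shows. Statements on the series, on what has been measured and on what is new or still open speak of the compounds shown alone.

Working notes on the salicylanilide series.

Compound 1 `O=C(Nc1ccc(OC(F)(F)F)cc1)c1cc(F)ccc1O` gives 780 nM in a functional assay on KG-1 cells (Homo sapiens) for cytotoxicity, read by luminescence and CellTiter-Glo, with a stated time of 3 days; a higher number here means a weaker inhibitor, a lower number a stronger inhibitor. Compound 2 `O=C(Nc1ccc(C(F)(F)F)cc1)c1cc(F)ccc1O` gives 1700 nM in this assay. The change between them, (trifluoromethyl in place of trifluoromethoxy on an aromatic carbon), gave a 2.2-fold higher number from compound 1 to compound 2 (0.34 log units; beyond the scatter).

Compound 3 `O=C(Nc1ccc(OC(F)(F)F)c(Cl)c1)c1cc(Cl)ccc1O` gives 460 nM in this assay. The difference between the core of compound 3 and the core of compound 1 is not broken down here; the two values lie within the usual scatter of each other.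

Compound 4 `O=C(Nc1ccc(C(F)(F)F)c(Cl)c1)c1cc(Cl)ccc1O` has not yet been measured. It differs from compound 3 by trifluoromethyl in place of trifluoromethoxy on an aromatic carbon. This is the same kind of change as that from compound 1 to compound 2, though not the same: in compound 3 the place is also ortho to a chloro group, which is absent in the pair of compound 1 and compound 2.

Going by the values given here, with only one measured example of this change, compound 4 is expected to move by a step of about a 2.2-fold higher number from compound 3 to compound 4 (0.34 log units; beyond the scatter) in this assay, resting on the step from compound 1 to compound 2, a 2.2-fold higher number from compound 1 to compound 2 (0.34 log units; beyond the scatter). Compound 4 is therefore estimated at 1000 nM, with a range of 450 nM to 2300 nM.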

Compound 4, half-maximal inhibitory concentration: 450 nM
Compound 4: middle estimate off by 2.2-fold (0.35 log units), on the high side; measured number inside the range.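

In this assay, trifluoromethyl in place of trifluoromethoxy on the core of compound 3 gives a 1.0-fold lower number from compound 3 to compound 4 (0.01 log units; within the scatter), a step within the scatter, while the same change on the core of compound 1 gives a 2.2-fold higher number from compound 1 to compound 2 (0.34 log units; beyond the scatter), a step beyond it. Set side by side, the two steps do not differ beyond what repeated measurement allows: the same change on two cores in this assay, a 2.2-fold higher number (0.34 log units; beyond the scatter) from compound 1 to compound 2 and a 1.0-fold lower number (0.01 log units; within the scatter) from compound 3 to compound 4, 2.2-fold (0.35 log units) apart, within the scatter of two such steps

This is consistent with the change carrying from one core to the other, but two pairs do not fix the size of the step on either core, and they do not show whether the chloro groups of compound 3 and compound 4 alter it.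

The compounds shown leave open how a nitrile, a methoxy group or an amine would read at this place on the aromatic carbon. They also leave open what each of the two chloro groups does alone, since the cores of compound 1 and compound 3 differ in more than one place.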